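This account rests on a few compounds, and the source may have more. Where it says the series, first, only, none or still open, it means among the compounds named here.

In a functional assay, with a stated time of 15 min (a lower number here means that less compound is needed, a higher number that more compound is needed for the effect), compound 1 `CCCCCCCCCC(=O)Nc1ccc(O)c2ccccc12` gives 18000 nM. Compound 2 `CN(C)c1ccc(O)c2ccccc12` gives 18000 nM, so the two stand level, within the usual scatter of repeated measurements. Compound 3 `CC(=O)Oc1ccc(N)c2ccccc12` behaves differently, and its reading is a limit of the assay and not a number: > 1000000 nM.

The next compound to be tested is compound 4 `NCc1ccc(O)c2ccccc12`, which keeps the core of compound 2 and alters one group: aminomethyl in place of dimethylamino on an aromatic carbon. The change sits on an aromatic carbon, para to a hydroxy group. Going by the values given here, no pair of measured compounds differs in one place only, so this assay offers no direct precedent for this swap. The closest guide is the pair already in hand. The group para to a hydroxy group differs widely between them, yet compound 1 gives 18000 nM and compound 2 gives 18000 nM. On that basis, only a modest step is expected, possibly none beyond the scatter, and slightly more likely towards a higher number, meaning that more compound would be needed. The expected change is a 1.7-fold higher number from compound 2 to compound 4 (0.22 log units; within the scatter). For compound 4 the estimated value is 30000 nM, with an expected range from 6000 nM to 150000 nM.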

Compound 4, half-maximal effective concentration: 260000 nM
The estimate for compound 4 lay 8.7-fold (0.94 log units) below the measured number, and the stated range ends below it.
By their numbers in this assay, from the lowest: compounds 1 and 2 (each within the scatter of the next); then compound 4. At a limit, above all of these: compound 3.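

In this assay, the position para to a hydroxy group turns out to be sensitive to this change: aminomethyl in place of dimethylamino gives a 14-fold higher number from compound 2 to compound 4 (1.16 log units; beyond the scatter). Going by these compounds alone, the earlier readings, with compound 1 at 18000 nM and compound 2 at 18000 nM, showed only that two very different groups can stand level at this place, and the new step shows that this does not extend to every group placed there. Aminomethyl has fewer heavy atoms than dimethylamino and carries a hydrogen-bond donor that dimethylamino lacks, but a single step cannot show which of these differences matters, if either does.

Still open, going by these compounds, is where a plain amine, a methylamino group or a dimethylaminomethyl group would fall at this place, and such groups could separate the role of the nitrogen's substituents from that of the added carbon link to the ring. Compound 3 is recorded only at a limit of the assay and not at a number, so any further rise in the number could be followed only up to that ceiling: the limit of > 1000000 nM in this assay, at which 1 of the 4 values shown sits.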